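A few compounds are considered here, and "the series" means these few. Any claim that something is new, unique, unknown or untested is made for them only; others in the source may bear on it.

Working notes on the hydrazone aryl group of this series.

Compound 1 `COc1ccc(OC)c(/C=N/NC(=O)Nc2ccc(Oc3ccnc(-c4nncn4CCN(C)C)c3)c(F)c2)c1` gives 6400 nM in a functional assay on U-87MG ATCC cells (Homo sapiens) for cytotoxicity, read by MTT assay, with a stated time of 72 h; a higher number here means a weaker inhibitor, a lower number a stronger inhibitor. Compound 2 `CN(C)CCn1cnnc1-c1cc(Oc2ccc(NC(=O)N/N=C/c3ccc(O)cc3)cc2F)ccn1` gives 7750 nM in this assay, which is the higher of the two numbers in hand, though the nearest value, that of compound 1, sits within the scatter: a 1.2-fold higher number from compound 1 to compound 2 (0.08 log units; within the scatter). Compound 3 `COc1cc(/C=N/NC(=O)Nc2ccc(Oc3ccnc(-c4nncn4CCN(C)C)c3)c(F)c2)ccc1O` reaches only the limit of > 100000 nM in this assay, so no number is known for it; the limit of > 100000 nM in this assay, at which 1 of the 3 values shown sits, marks that one of the three readings sits there. The two steps onto compound 3 are large: an at least 15-fold higher number from compound 1 to compound 3 (1.19 log units; beyond the scatter) and an at least 12-fold higher number from compound 2 to compound 3 (1.11 log units; beyond the scatter).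

Compound 4 `CN(C)CCn1cnnc1-c1cc(Oc2ccc(NC(=O)N/N=C/c3ccc(Cl)cc3Cl)cc2F)ccn1` is not yet measured in this assay. It differs from compound 2 by 2,4-dichlorophenyl in place of 4-hydroxyphenyl on a carbon with a double bond to nitrogen. For the measured compounds named here, no measured step introduces chlorine, so the only comparable change is the exchange of aryl groups on that carbon in compound 1 to compound 2, which stayed within the scatter; the large steps onto compound 3 concern the added methoxy and do not carry over. A shift of modest size, in either direction, is therefore expected for this assay, with the chance of a limit kept in mind. Compound 4 is estimated at 5000 nM, within 1500 nM to 20000 nM, which means an expected step of a 1.6-fold lower number from compound 2 to compound 4 (0.19 log units; within the scatter).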

Compound 4, half-maximal inhibitory concentration: 2330 nM
Beside the measured number, compound 4's estimate is 2.1-fold (0.33 log units) above it; measured number inside the range.
By their numbers in this assay, from the lowest: compound 4; then compounds 1 and 2 (each within the scatter of the next). At a limit, above all of these: compound 3.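

The aryl group on the carbon with a double bond to nitrogen now gives a gain beyond the scatter, where the exchange between the two earlier numbered values did not: a 3.3-fold lower number from compound 2 to compound 4 (0.52 log units; beyond the scatter), and likewise a 2.7-fold lower number from compound 1 to compound 4 (0.44 log units; beyond the scatter). At the far end of the series, the gap to 2,4-dichlorophenyl is an at least 42-fold lower number from compound 3 to compound 4 (1.63 log units; beyond the scatter), a step that starts from a limit and not from a number. Compound 3 remains at a limit: the limit of > 100000 nM in this assay, at which 1 of the 4 values shown sits.

From the compounds shown here alone, whether both chlorines are needed remains open, as does how a phenyl carrying a single chlorine, a bromine or a trifluoromethyl group would read in this assay. Going by these compounds, all four compounds share one core, so it is also open whether this step would hold with a morpholine at the end of the side chain.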